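The compounds below may be only part of what the source reports. "The series", "measured", "known", "first", "only" and "open" are said of these compounds alone.

Of the compounds shown here, three have so far been tested in a functional assay on MCF7 cells (Homo sapiens) for inhibition, read by sulforhodamine B assay, with a stated time of 48 h; on this read-out lower numbers stand for stronger inhibition of growth and higher numbers for weaker inhibition of growth. Compound 1 `CCOC(=O)c1nn(-c2ccccc2)c(-c2ccc(Cl)cc2)c1CNC(C)(C)C` gives 72400 nM; > 559000 nM (2 entries), so its record holds more than one entry. One of these entries is a limit of the assay and not a number. Compound 2 `CCOC(=O)c1nn(-c2ccc(Cl)cc2)c(-c2ccc([N+](=O)[O-])cc2)c1CNC(C)(C)C` gives > 548000 nM; 205000 nM (2 entries), again more than one entry. Here too, one of the entries is a limit of the assay and not a number. Compound 3 `CC(C)(C)NCc1c(C(=O)O)nn(-c2ccccc2)c1-c1ccc(Cl)cc1` gives > 652000 nM, which is a limit of the assay and not a number. Compound 3 therefore has no exact place on the scale.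

Compound 4 `CC(C)(C)NCc1c(C(=O)O)nn(-c2ccccc2)c1-c1ccccc1` is compound 3 with a single small edit: hydrogen in place of chloro on an aromatic carbon. This puts hydrogen in place of chloro on an aromatic carbon, so that 4-chlorophenyl becomes phenyl. Within the data shown here, no two measured compounds differ in only one place, so the data give no direct guide to the size of this edit.

The expectation has to start from compound 3, whose limit of > 652000 nM is the only anchor. The estimated step, an at least 1.0-fold lower number from compound 3 to compound 4 (0.03 log units; that floor lies within the scatter), is expected to stay within the usual scatter of this assay, with no clear direction. Compound 4 is expected at 600000 nM, with an estimated range from 250000 nM to 900000 nM. The result may well arrive as a limit only.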

Compound 4, concentration for 50% growth inhibition: > 716000 nM
Compound 4: only a limit was reported; the forecaster's own chance of this, stated with the estimate: 70%; middle value at least 1.1-fold (0.07 log units) away from the limit.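

Compound 3 and compound 4 are each reported only as a limit and not as a number, and the step between them cannot be read. The compounds shown leave open whether going from 4-chlorophenyl to phenyl changes growth inhibition at all, and if it does, in which direction and by how much.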